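From 4-methoxyphenyl to 3-fluorophenyl on a shared core

A few compounds are considered here, and "the series" means these few. Any claim that something is new, unique, unknown or untested is made for them only; others in the source may bear on it.

Measured in a functional assay on K562 cells (Homo sapiens) for antiproliferative activity, read by MTT assay, with a stated time of 72 h; a lower number here means a stronger inhibitor, a higher number a weaker inhibitor:
Compound 1 `COc1ccc(-c2ncnn2-c2cc(OC)c(OC)c(OC)c2)cc1` gives 950 nM
Compound 2 `COc1cc(-n2ncnc2-c2ccc(OC(C)C)cc2)cc(OC)c1OC` gives 800 nM

Among the measured compounds shown here, these are the only two numbers so far, and compound 1 stands level with compound 2 within the scatter (a 1.2-fold lower number from compound 1 to compound 2 (0.07 log units; within the scatter)). Compound 3 `COc1cc(-n2ncnc2-c2cccc(F)c2)cc(OC)c1OC` differs from compound 1 at one place (3-fluorophenyl in place of 4-methoxyphenyl on an aromatic carbon): 3-fluorophenyl in place of 4-methoxyphenyl on an aromatic carbon. For the measured compounds named here, the single measured step bears on this only partly. It swaps methyl for isopropyl on an oxygen on an aromatic ring, and compound 2 keeps that oxygen (800 nM). Going by the values given here, compound 3 has no such oxygen, and no measured compound shows what losing it does. A cautious move to a higher number is therefore expected (a 3.2-fold higher number from compound 1 to compound 3 (0.50 log units; beyond the scatter)). For compound 3 the estimated value is 3000 nM (range 700 nM to 13000 nM).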

Compound 3, half-maximal inhibitory concentration: > 10000 nM
Compound 3 gave a limit, no number; the forecaster's own chance of this, stated with the estimate: 10%; middle value at least 3.3-fold (0.52 log units) away from the limit.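

In this assay, this aromatic carbon of the shared core proves far less forgiving than the earlier pair suggested, with 3-fluorophenyl in place of 4-methoxyphenyl giving an at least 10-fold higher number from compound 1 to compound 3 (1.02 log units; beyond the scatter). Compound 3 reads > 10000 nM, which is a limit of the assay and not a number. The printed step is therefore only the smallest size the result allows, and the real gap could be wider: the limit of > 10000 nM in this assay, at which 1 of the 3 values shown sits.

This single swap removes the methoxy group and adds a fluorine at once, so the compounds shown cannot say which of the two matters, or whether both do. On these data alone, a plain phenyl group at this carbon would separate those two changes, and how an aminophenyl group would read here also remains open.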